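Ethoxycarbonyl on the Alkyne of a Vinyl Ether Ester

The compounds below may be only part of what the source reports. "The series", "measured", "known", "first", "only" and "open" are said of these compounds alone.

The measured compounds are:
Compound 1, `C#CCO/C=C/C(=O)OC`, gives > 100000 nM in a functional assay on HBL-100 cells (Homo sapiens) for antiproliferative activity, read by sulforhodamine B assay, with a stated time of 48 h (on this read-out higher numbers stand for weaker inhibition of growth and lower numbers for stronger inhibition of growth), which is a limit of the assay.
Compound 2, `CC1CCC(C(C)C)C(OC(=O)C#CC(O/C=C/C(=O)OC2CC(C)CCC2C(C)C)C(C)C)C1`, gives > 100000 nM in this assay, again a limit.
Compound 3, `CCC(C)C(C#CC(=O)OC)O/C=C/C(=O)OC`, gives 340 nM in this assay.

Compound 1 stands at a limit rather than at a number, and it shares that position with compound 2 (the limit of > 100000 nM in this assay, at which 2 of the 3 values shown sit). Only compound 3 returns a measured value. For the measured compounds named here, no step between measured compounds that differ in one place is available, so the move to compound 4 is judged from the structures alone.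

Compound 4, `CCOC(=O)C#CCO/C=C/C(=O)OC`, differs from compound 1 by ethoxycarbonyl in place of hydrogen on a triple-bonded carbon. Since compound 1 sits at a limit, the step can only be read as a move toward stronger growth inhibition, if any. Because compound 3 gives 340 nM, compound 4 is expected to reach a measurable value, though weaker than that of compound 3, since it lacks the branched chain of compound 3. Compound 4 is estimated at 6000 nM, ranging from 600 nM to 60000 nM, which means an expected step of an at least 16-fold lower number from compound 1 to compound 4 (1.22 log units; beyond the scatter).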

Compound 4, concentration for 50% growth inhibition: 2400 nM
Estimate against measurement, compound 4: 2.5-fold (0.40 log units) above; low and high end bracket the measured number.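

In this assay, for the compounds shown here, ethoxycarbonyl in place of hydrogen on a triple-bonded carbon gives an at least 41-fold lower number from compound 1 to compound 4 (1.61 log units; beyond the scatter), the first change in one place that can be read. This shows that the group carried on this carbon can decide whether the core of compound 1 gives a measurable value, with no other change to that core. The step is a lower bound on the change and not its full size, as compound 1 stands at a limit of the assay: the limit of > 100000 nM in this assay, at which 2 of the 4 values shown sit.

The compounds shown do not tell whether the gain depends on the ester itself or whether other groups on this carbon would serve as well, such as a carboxylic acid, a primary amide or a nitrile. They also leave open how a longer chain in place of the ethyl part of the ester would read.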